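Urea ring size in a quinoline amine series

The source may report more compounds than this note shows. Statements on the series, on what has been measured and on what is new or still open speak of the compounds shown alone.

Measured so far in a functional assay on MCF7 cells (Homo sapiens), read by MTT assay, with a stated time of 72 h; a lower number here means a stronger inhibitor, a higher number a weaker inhibitor:
Compound 1 `COc1cc(NC(C)CCCNC(=O)NC(c2ccccc2)c2ccccc2)c2ncccc2c1` gives a limit, > 100000 nM.
Compound 2 `COc1cc(NC(C)CCCNC(=O)NCc2ccccc2)c2ncccc2c1` gives 25000 nM.
Compound 3 `COc1cc(NC(C)CCCNC(=O)NC2CCCCC2)c2ncccc2c1` gives 41000 nM.

Compound 3 holds the highest of the two numbers shown, with compound 2 nearest at a 1.6-fold higher number from compound 2 to compound 3 (0.21 log units; within the scatter); the remaining value is a limit. Compound 4 `COc1cc(NC(C)CCCNC(=O)NC2CCCC2)c2ncccc2c1` differs from compound 3 by cyclopentyl in place of cyclohexyl on an amide-type nitrogen. Among the measured compounds shown here, the only step that bears on this change is the swap of benzyl for cyclohexyl on the same nitrogen, a 1.6-fold higher number from compound 2 to compound 3 (0.21 log units; within the scatter), which stayed within the scatter; the larger step of an at least 4.0-fold lower number from compound 1 to compound 2 (0.60 log units; beyond the scatter) concerns loss of a phenyl and is less comparable. A change of one carbon in the ring is therefore expected to move the number little, giving an expected step of a 1.1-fold higher number from compound 3 to compound 4 (0.04 log units; within the scatter) in this assay. Compound 4 is estimated at 45000 nM, within 20000 nM to 95000 nM.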

Compound 4, half-maximal inhibitory concentration: 30000 nM
Compound 4: the middle estimate sits 1.5-fold (0.18 log units) above what was measured; the range from low to high includes it.
By their numbers in this assay, from the lowest: compounds 2, 4 and 3 (each within the scatter of the next). At a limit, above all of these: compound 1.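

In this assay, shrinking the ring on the amide-type nitrogen stays within the scatter, a 1.4-fold lower number from compound 3 to compound 4 (0.14 log units; within the scatter), as does replacing benzyl with cyclopentyl, a 1.2-fold higher number from compound 2 to compound 4 (0.08 log units; within the scatter). Cyclohexyl, cyclopentyl and benzyl at this position therefore cannot be told apart in this assay, so ring size shows no readable effect here. Compound 1 alone stands apart, as a limit: the limit of > 100000 nM in this assay, at which 1 of the 4 values shown sits.

From the compounds shown here alone, whether a much smaller group such as methyl, or a charged one such as a carboxylic acid or an amine, on this nitrogen would move the number remains open.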